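The compounds below may be only part of what the source reports. "The series", "measured", "known", "first", "only" and "open" are said of these compounds alone.

Of the compounds shown here, three have so far been tested in a functional assay on NCI-H1993 cells (Homo sapiens) for inhibition, read by CCK-8 assay, with a stated time of 72 h; a lower number here means a stronger inhibitor, a higher number a weaker inhibitor. Compound 1 `Cc1c(C(C)n2cnc3ncc(-c4cnn(C)c4)nc32)ccc2ncccc12` gives 206 nM, compound 2 `CC(c1c(F)cc2ncccc2c1F)n1cnc2ncc(-c3ccccc3)nc21` gives 514 nM, and compound 3 `CC(NC/N=C/c1cnn(C)c1)c1ccc2ncccc2c1` gives 197 nM. Compound 3 and compound 1 lie within the usual scatter of each other, so neither can be ranked above the other. Compound 2 has a higher number than compound 3, and that gap lies beyond the scatter.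

The next compound, compound 4 `CC(NC/N=C/c1cn[nH]c1)c1ccc2ncccc2c1`, differs from compound 3 in a single place: hydrogen in place of methyl on an aromatic nitrogen. This puts hydrogen in place of methyl on an aromatic nitrogen, turning 1-methyl-1H-pyrazol-4-yl into 1H-pyrazol-4-yl. Going by the values given here, no two compounds measured so far differ in only one place, so the data give no direct guide to what this change does in this assay. The forecast is therefore tentative. Starting from compound 3 at 197 nM, the loss of so small a group is not expected to move the number far. The expected change is a 1.3-fold higher number from compound 3 to compound 4 (0.12 log units; within the scatter), a small move toward a weaker inhibitor that may not clear the scatter. For compound 4 the estimated value is 260 nM, with an expected range from 90 nM to 750 nM.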

Compound 4, half-maximal inhibitory concentration: 519 nM
For compound 4 the middle estimate is 2.0-fold (0.30 log units) below the measured one, within the range that was stated.
By their numbers in this assay, from the lowest: compounds 3 and 1 (each within the scatter of the next); then compounds 2 and 4 (each within the scatter of the next).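

In this assay, taking the methyl off the aromatic nitrogen gives a 2.6-fold higher number from compound 3 to compound 4 (0.42 log units; beyond the scatter), so this position does respond to the change: the loss of one carbon, with no ring and no net charge involved, is enough to clear the scatter. This is the first pair shown that differs in only one place, which makes it the first direct reading of a single change in this series, and here 1-methyl-1H-pyrazol-4-yl gives the stronger inhibitor and 1H-pyrazol-4-yl the weaker. Nothing at hand bears on what lies behind the step, so it stands as an observation without an explanation.

On these data alone, with only methyl and hydrogen compared on this nitrogen, it remains open whether a longer chain such as ethyl, or a chain ending in an alcohol, would keep the number low or lower it further. As far as these compounds go, it is also open whether the same swap would move the number the same way on compound 1, which carries the same 1-methyl-1H-pyrazol-4-yl group on a different core.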